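Carbamate in place of benzyl ether on the shared core

The source may hold more compounds than are shown below. What is called first, only, known or untested is meant among the compounds shown, and "the series" means these compounds.

Measured in a functional assay on PANC-1 cells (Homo sapiens) for inhibition, read by MTT assay, with a stated time of 24 h, tested at 10 uM; on this read-out lower numbers stand for less inhibition and higher numbers for more inhibition at the one concentration tested (going by the name of the read-out):
compound 1 `CC(C)=CCC/C(C)=C/CC1Cc2c(O)cc(=O)n(CCCO)c2CC1(C)C` gives 0%
compound 2 `CC(C)=CCC1Cc2c(OCc3ccccc3)cc(=O)n(CCCO)c2CC1(C)C` gives 11.1%
compound 3 `CC(C)=CCC1Cc2c(OCCCNS(=O)(=O)c3ccc(Br)cc3)cc(=O)n(CCCO)c2CC1(C)C` gives 3.7%

All three numbers in this assay are small. Compound 2 gives the highest of the three, but the gap to compound 3 lies within the scatter of repeated measurements, so no order between compound 2 and compound 3 can be read from these two values. The gap from compound 2 down to compound 1 lies beyond the scatter, and compound 1 is the only one of the three that shows no inhibition at all at the concentration tested.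

Among the compounds with values here, no pair among the measured compounds differs in a single place, so no measured step is available as a guide for the next compound.

Compound 4 `COc1ccccc1NC(=O)Oc1cc(=O)n(CCCO)c2c1CC(CC=C(C)C)C(C)(C)C2` is not yet measured in this assay. It differs from compound 2 as follows: (2-methoxyphenyl)carbamoyl in place of benzyl on an oxygen on an aromatic ring. The substituent on the aromatic oxygen is thus exchanged while the rest of compound 2 is kept.

Given that every measured number in this assay sits in the low range and the ether substituent varies among them without a large spread, the step from compound 2 to compound 4 is expected to be small, a number 3.1 percentage points lower from compound 2 to compound 4 (within the scatter), with no direction beyond the scatter. For compound 4 the estimate in this assay is 8%, within a range from 0% to 25%.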

Compound 4, a percentage reported as inhibition, at one concentration (the size of the read-out at that concentration, not a potency): 0%
For compound 4 the middle estimate is 8 percentage points above the measured one; low and high end bracket the measured number.
By their numbers in this assay, from the lowest: compounds 1, 4, 3 and 2 (each within the scatter of the next, the first and the last beyond it).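

In this assay, within the data shown here, the exchange of benzyl for (2-methoxyphenyl)carbamoyl on an oxygen on an aromatic ring gives a number 11.1 percentage points lower from compound 2 to compound 4 (beyond the scatter) and is the only single-place step available. It shows that this oxygen substituent can shift the read-out beyond the scatter, although the step is modest and starts from a low number. With the new group, which adds a hydrogen-bond donor and hydrogen-bond acceptors to the substituent, compound 4 gives 0% at the one concentration tested, and no data here explain the loss of inhibition.

Among these compounds, the single step does not separate the contribution of the carbamate link from that of the 2-methoxyphenyl ring, so an unsubstituted phenyl carbamate or a 2-methoxybenzyl ether would be needed to tell them apart. Also open, as far as these compounds go, is whether any group on this oxygen can lift inhibition well clear of the low range seen so far, for instance a chain ending in an amine or a carboxylic acid.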